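Methyl on the acid-bearing carbon: a small step expected

The source may report more compounds than this note shows. Statements on the series, on what has been measured and on what is new or still open speak of the compounds shown alone.

Of the compounds shown here, three with a shared core have been measured in a functional assay on CHO cells for agonist activity at Free fatty acid receptor 1 (Homo sapiens), read by FLIPR and calcium flux; a lower number here means that less compound is needed, a higher number that more compound is needed for the effect. Compound 1 `COc1cc(C)c(-c2cccc(COc3ccc(S(=O)(=O)CC(=O)O)cc3)c2)c(C)c1` gives 57.5 nM; compound 2 `CCCOc1cc(C)c(-c2cccc(COc3ccc(S(=O)(=O)CC(=O)O)cc3)c2)c(C)c1` gives 69.2 nM; compound 3 `Cc1cc(OCC(C)C)cc(C)c1-c1cccc(COc2ccc(S(=O)(=O)CC(=O)O)cc2)c1` gives 95.5 nM. The steps among them are small: a 1.2-fold higher number from compound 1 to compound 2 (0.08 log units; within the scatter) and a 1.7-fold higher number from compound 1 to compound 3 (0.22 log units; within the scatter), so no order can be read from these three numbers.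

Compound 4 `COc1cc(C)c(-c2cccc(COc3ccc(S(=O)(=O)C(C)C(=O)O)cc3)c2)c(C)c1` is not yet measured. It differs from compound 1 by methyl in place of hydrogen on a saturated chain carbon bound to a carbonyl carbon and a sulfonyl sulfur. A change of the same kind is already seen between compound 2 and compound 3, which differ by methyl in place of hydrogen on a saturated chain carbon bound to two saturated chain carbons, and there the step is a 1.4-fold higher number from compound 2 to compound 3 (0.14 log units; within the scatter). The two changes are the same kind of change, not the same: in the measured pair the place is on a saturated chain carbon bound to two saturated chain carbons, whereas in compound 4 the place is on a saturated chain carbon bound to a carbonyl carbon and a sulfonyl sulfur. The two cores themselves differ by hydrogen in place of ethyl on a saturated chain carbon bound to an oxygen on an aromatic ring, which on its own moves the number only within the usual scatter.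

For the measured compounds named here, with only one measured example of a methyl entering in place of hydrogen, and that one at a different place, the expectation for compound 4 rests on the step from compound 2 to compound 3 being within the scatter: the step from compound 1 to compound 4 is estimated as a 1.3-fold higher number from compound 1 to compound 4 (0.12 log units; within the scatter). Compound 4 is therefore expected to give about 75 nM in this assay, most likely between 35 nM and 160 nM.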

Compound 4, half-maximal effective concentration in the Free fatty acid receptor 1 assay: > 1000 nM
Compound 4 was reported as a limit; the forecaster's own chance of this, stated with the estimate: 2%; middle value at least 13-fold (1.12 log units) away from the limit.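

In the Free fatty acid receptor 1 assay, compound 4 gives > 1000 nM, which is a limit of the assay and not a number. Methyl in place of hydrogen on a saturated chain carbon bound to a carbonyl carbon and a sulfonyl sulfur produces an at least 17-fold higher number from compound 1 to compound 4 (1.24 log units; beyond the scatter), and this step does not match the earlier methyl step on the other core: the same change on two cores in the Free fatty acid receptor 1 assay, a 1.4-fold higher number (0.14 log units; within the scatter) from compound 2 to compound 3 and an at least 17-fold higher number (1.24 log units; beyond the scatter) from compound 1 to compound 4, at least 12-fold (1.10 log units) apart, beyond the scatter of two such steps So in this series, a methyl step that stays within the scatter at one place cannot be assumed to do the same at another, but these two steps differ in both place and core, and they do not show which of the two matters.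

In a physicochemical assay for lipophilicity, using the shake flask method, in phosphate buffer, measured as octanol-water partition, with a stated time of 24 h, at pH 7.4, tested at 100 uM (on this read-out higher numbers stand for higher lipophilicity and lower numbers for lower lipophilicity), compound 1 gives 2.45 and compound 4 has "not determined" (no result reported), so this read-out offers no comparison between them. Still open, as far as these compounds go, is whether the same methyl at this place on the core of compound 2 gives a similar step, and whether a group other than methyl, such as a fluorine or a hydroxyl on that saturated chain carbon, gives a step of this size.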